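A few compounds are considered here, and "the series" means these few. Any claim that something is new, unique, unknown or untested is made for them only; others in the source may bear on it.

Measured compounds:
Compound 1 `COC(=O)[C@@]1(C)CCC=C2[C@@H]1CC[C@@H](C)[C@]2(C)Cc1c(C)[nH]c2ccc(C)cc12` — 26000 nM
Compound 2 `COC(=O)[C@@]1(C)CCC=C2[C@@H]1CC[C@@H](C)[C@]2(C)Cc1c(C)[nH]c2c(Br)cccc12` — 27000 nM
Compound 3 `COC(=O)[C@@]1(C)CC[C@@H]2C3=C1CC[C@@H](C)[C@]3(C)Cc1c2[nH]c2ccc(C)cc12` — 16000 nM

Of the compounds shown here, three have been measured in a functional assay on A549 cells (Homo sapiens) for inhibition, read by sulforhodamine B assay, with a stated time of 48 h; on this read-out lower numbers stand for stronger inhibition of growth and higher numbers for weaker inhibition of growth. Compound 3 gives 16000 nM, the lowest of the three numbers, while compound 1 gives 26000 nM and compound 2 gives 27000 nM. The gaps from compound 3 to each of the other two lie within the usual scatter, so no order among the three can be claimed. Compound 4 `COC(=O)[C@@]1(C)CC[C@@H]2C3=C1CC[C@@H](C)[C@]3(C)Cc1c2[nH]c2ccc(OC)cc12` differs from compound 3 in one place: methoxy in place of methyl on an aromatic carbon. Within the data shown here, no pair of measured compounds isolates this change, so nothing measured tells how it shifts the numbers in this assay. Compound 3 is the nearest measured neighbour of compound 4, and the change touches only the outer aromatic ring while the rest of the core is kept unchanged. The expected step is no change at the digits printed from compound 3 to compound 4 (within the scatter), within the scatter. The estimate for compound 4 in this assay is 16000 nM, with a range from 6000 nM to 40000 nM.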

Compound 4, concentration for 50% growth inhibition: 7700 nM
For compound 4 the middle estimate is 2.1-fold (0.32 log units) above the measured one; low and high end bracket the measured number.
By their numbers in this assay, from the lowest: compound 4; then compounds 3, 1 and 2 (each within the scatter of the next).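

In this assay, methoxy in place of methyl on this aromatic carbon gives a 2.1-fold lower number from compound 3 to compound 4 (0.32 log units; beyond the scatter), a modest step but beyond the scatter, and the only step that can be read among these compounds. It shows that this position on the six-membered aromatic ring is not silent: with the rest of the core kept unchanged, the group placed there alone shifts the number. Nothing available explains why this change lowers the number.

The compounds shown leave open how an amine, a hydroxyl or a longer chain such as ethoxy on this same aromatic carbon would read. They also leave open whether the same change gives a similar step on the core of compound 1, as the pair of compound 3 and compound 4 is the only one that carries it.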